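From 4-methoxyphenyl to 3-nitrophenyl on the carbonyl carbon

This account rests on a few compounds, and the source may have more. Where it says the series, first, only, none or still open, it means among the compounds named here.

In a functional assay on MDA-MB-231 cells (Homo sapiens) for antiproliferative activity, read by MTT assay, with a stated time of 72 h (on this read-out higher numbers stand for weaker inhibition and lower numbers for stronger inhibition), compound 1 `CC1=CC[C@H]2[C@H](CC[C@]2(C)O)C(C)(C)[C@@H]1CC[C@H]1[C@]2(C)CC[C@H](OC(=O)NS(=O)(=O)c3ccc(C)cc3)C(C)(C)O[C@H]2CC[C@@]1(C)O` gives 47100 nM while compound 2 `COc1ccc(C(=O)O[C@H]2CC[C@]3(C)[C@H](CC[C@@](C)(O)[C@H]3CC[C@@H]3C(C)=CC[C@H]4[C@H](CC[C@]4(C)O)C3(C)C)OC2(C)C)cc1` gives 30600 nM and the two sit within the scatter of each other. Compound 3 `CC1=CC[C@H]2[C@H](CC[C@]2(C)O)C(C)(C)[C@@H]1CC[C@H]1[C@]2(C)CC[C@H](OC(=O)c3cccc([N+](=O)[O-])c3)C(C)(C)O[C@H]2CC[C@@]1(C)O` has 3-nitrophenyl in place of 4-methoxyphenyl on a carbonyl carbon and no other difference from compound 2. Among the compounds with values here, the only measured step at this carbonyl carbon (a 1.5-fold lower number from compound 1 to compound 2 (0.19 log units; within the scatter)) put 4-methoxyphenyl in place of ((4-methylphenyl)sulfonyl)amino and stayed within the scatter. Within the data shown here, no measured compound holds a 3-nitrophenyl group, and a single step is thin support, so the range is kept wide. No step beyond the scatter is expected in this assay for this replacement. The estimated step (a 1.0-fold lower number from compound 2 to compound 3 (0.01 log units; within the scatter)) is correspondingly small. The expected value for compound 3 is 30000 nM (estimated range 13000 nM to 70000 nM).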

Compound 3, half-maximal inhibitory concentration: 34700 nM
Compound 3: middle estimate off by 1.2-fold (0.06 log units), on the low side; measured number inside the range.
By their numbers in this assay, from the lowest: compounds 2, 3 and 1 (each within the scatter of the next).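

In this assay the replacement of 4-methoxyphenyl by 3-nitrophenyl on the carbonyl carbon gives a 1.1-fold higher number from compound 2 to compound 3 (0.05 log units; within the scatter) and the replacement of ((4-methylphenyl)sulfonyl)amino by 3-nitrophenyl gives a 1.4-fold lower number from compound 1 to compound 3 (0.13 log units; within the scatter), so a single step at this carbonyl carbon has become a set of three groups. All three compounds lie within the scatter of one another, and no group tried so far separates from the others in this assay. A second aromatic group, with its substituent changed and named at a different ring number, thus leaves the read-out unresolved from compound 2. No evidence on hand bears on this result.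

The compounds shown leave open whether a group of another kind on this carbonyl carbon, such as an amine, a carboxylic acid or a longer alkyl chain, would give a step beyond the scatter. They also leave open whether the free alcohol without the carbonyl group would read any differently.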